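Swapping the Aryl Group on the Ring Nitrogen

The compounds below may be only part of what the source reports. "The series", "measured", "known", "first", "only" and "open" are said of these compounds alone.

Compound 3 `O=C1c2ccccc2S(=O)(=O)N1CCCCCCN1CCN(c2ccc(Cl)c(Cl)c2)CC1` gives 132 nM in an ADME assay on HEK293 cells for displacement of a labelled ligand from 5-hydroxytryptamine receptor 6 (Homo sapiens), read by radioligand binding, with a stated time of 1 h (a higher number here means a weaker inhibitor, a lower number a stronger inhibitor), the lowest number among the three measured compounds. Compound 1 `O=C1c2ccccc2S(=O)(=O)N1CCCCCCN1CCN(c2ccccc2Cl)CC1` gives 459 nM in this assay, and compound 2 `O=C1c2ccccc2S(=O)(=O)N1CCCCCCN1CCN(c2cccc(Cl)c2)CC1` gives 372 nM. The steps of a 3.5-fold lower number from compound 1 to compound 3 (0.54 log units; beyond the scatter) and a 2.8-fold lower number from compound 2 to compound 3 (0.45 log units; beyond the scatter) both lie beyond the scatter, whereas a 1.2-fold lower number from compound 1 to compound 2 (0.09 log units; within the scatter) does not.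

Compound 4 `O=C1c2ccccc2S(=O)(=O)N1CCCCCCN1CCN(c2ccccc2C(F)(F)F)CC1` has not yet been measured. It differs from compound 3 by 2-(trifluoromethyl)phenyl in place of 3,4-dichlorophenyl on an amine nitrogen in a ring. For the measured compounds named here, the steps that bear on this change are those that lead to compound 3: a 3.5-fold lower number from compound 1 to compound 3 (0.54 log units; beyond the scatter) shows what replacing 2-chlorophenyl by 3,4-dichlorophenyl did, and a 2.8-fold lower number from compound 2 to compound 3 (0.45 log units; beyond the scatter) shows what the added chloro did. Compound 4 carries 2-(trifluoromethyl)phenyl, and compound 1, which carries 2-chlorophenyl, is the closest measured analogy; compound 4 is therefore expected to lose most of the gain seen in a 3.5-fold lower number from compound 1 to compound 3 (0.54 log units; beyond the scatter), with a modest rise in number. The expected step is a 3.4-fold higher number from compound 3 to compound 4 (0.53 log units; beyond the scatter). Compound 4 is estimated at 450 nM in this assay, within a range from 180 nM to 1100 nM.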

Compound 4, inhibition constant: 1270 nM
Estimate against measurement, compound 4: 2.8-fold (0.45 log units) below, and the stated range ends below it.
By their numbers in this assay, from the lowest: compound 3; then compounds 2 and 1 (each within the scatter of the next); then compound 4.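

In this assay, trifluoromethyl in place of chloro on the aromatic carbon raises the number (a 2.8-fold higher number from compound 1 to compound 4 (0.44 log units; beyond the scatter)), so the two groups are not interchangeable on this phenyl ring, which the chlorinated compounds alone could not show. The 2-(trifluoromethyl)phenyl group on the amine nitrogen also gives a higher number than the 3-chlorophenyl group (a 3.4-fold higher number from compound 2 to compound 4 (0.53 log units; beyond the scatter)) and the 3,4-dichlorophenyl group (a 9.6-fold higher number from compound 3 to compound 4 (0.98 log units; beyond the scatter)), which places compound 4 highest of the four compounds. No measurement shown here accounts for these rises.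

From the compounds shown here alone, it remains open whether 3-(trifluoromethyl)phenyl or 4-(trifluoromethyl)phenyl on the same ring nitrogen would give a number closer to that of compound 3. Going by these compounds, the effect of a plain phenyl or a 2-methoxyphenyl group in this place also remains open, as does whether the order of these aryl groups would hold with a shorter chain.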